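A few compounds are considered here, and "the series" means these few. Any claim that something is new, unique, unknown or untested is made for them only; others in the source may bear on it.

Three compounds share a core in which a glycinamide chain carries an amino-ester group. Compound 1 `COC(=O)CCNC(=O)Cn1cc(C2=C(c3c[nH]c4ccccc34)C(=O)N(C)C2=O)c2ccccc21` bears the 2-(methoxycarbonyl)ethyl group and in a functional assay on Bel-7402 cells (Homo sapiens) for cytotoxicity, read by MTT assay, with a stated time of 24 h (a higher number here means a weaker inhibitor, a lower number a stronger inhibitor), compound 1 gives 28400 nM. Compound 2 `COC(=O)[C@@H](CC(C)C)NC(=O)Cn1cc(C2=C(c3c[nH]c4ccccc34)C(=O)N(C)C2=O)c2ccccc21` carries the 1-(methoxycarbonyl)-3-methylbutyl group in its place, and in this assay compound 2 gives 42400 nM, a change of a 1.5-fold higher number from compound 1 to compound 2 (0.17 log units; within the scatter). Compound 3 `CC[C@H](C)[C@@H](NC(=O)Cn1cc(C2=C(c3c[nH]c4ccccc34)C(=O)N(C)C2=O)c2ccccc21)C(=O)OC` carries the 1-(methoxycarbonyl)-2-methylbutyl group. In this assay compound 3 reaches only the limit of > 100000 nM, so its number is not known. The steps of an at least 3.5-fold higher number from compound 1 to compound 3 (0.54 log units; beyond the scatter) and an at least 2.3-fold higher number from compound 2 to compound 3 (0.37 log units; beyond the scatter) both point toward a weaker inhibitor at compound 3, though only the limit of > 100000 nM in this assay, at which 1 of the 3 values shown sits, marks where it stands.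

Compound 4 `COC(=O)[C@H](NC(=O)Cn1cc(C2=C(c3c[nH]c4ccccc34)C(=O)N(C)C2=O)c2ccccc21)[C@@H](C)O` differs from compound 3 by hydroxy in place of ethyl on a saturated chain carbon bound to two saturated chain carbons. Among the compounds with values here, none of the measured steps changes this saturated chain carbon in the same way; the closest, sec-butyl to isobutyl between compound 2 and compound 3, moved the number beyond the scatter. With compound 3 known only as a limit, the step of an at least 1.1-fold lower number from compound 3 to compound 4 (0.04 log units; that floor lies within the scatter) that is expected here has little to anchor it. Compound 4 is therefore estimated at 90000 nM, within a range from 30000 nM to 300000 nM, and it may well again report only a limit.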

Compound 4, half-maximal inhibitory concentration: > 100000 nM
Compound 4: a limit, no number; the forecaster's own chance of this, stated with the estimate: 50%; middle value at least 1.1-fold (0.04 log units) away from the limit.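

In this assay compound 4 also stands only as a limit, so this step cannot be read, and the change from ethyl to hydroxy on this saturated chain carbon has no measurable size. Against the measured compounds the picture is firmer: 1-hydroxyethyl in place of isobutyl gives an at least 2.3-fold higher number from compound 2 to compound 4 (0.37 log units; beyond the scatter), and 2-hydroxy-1-(methoxycarbonyl)propyl in place of 2-(methoxycarbonyl)ethyl gives an at least 3.5-fold higher number from compound 1 to compound 4 (0.54 log units; beyond the scatter). The sec-butyl chain of compound 3 is therefore no longer alone in lying on the weaker side of compound 1 and compound 2, since the 1-hydroxyethyl chain of compound 4 lies there too, and the limit now holds compound 3 and compound 4: the limit of > 100000 nM in this assay, at which 2 of the 4 values shown sit.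

From the compounds shown here alone, how far compound 3 and compound 4 each lie beyond that limit stays unknown, and so does whether they differ from each other at all. Going by these compounds, it also remains open whether an amine or a carboxylic acid in place of the hydroxy on this saturated chain carbon, or a longer chain in place of the 1-hydroxyethyl, would bring the number back into the measurable range.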